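The source may report more compounds than this note shows. Statements on the series, on what has been measured and on what is new or still open speak of the compounds shown alone.

Of the compounds shown here, two of this fused tricyclic series have been measured in an assay on HEK293 cells for binding affinity to Neuronal acetylcholine receptor; alpha4/beta2 (Homo sapiens) (a lower number here means a stronger inhibitor, a higher number a weaker inhibitor), and the unmeasured compound 3 is the next one to be placed beside them. Compound 1 `Nc1ccc2c(c1)C1CNCC2C1` gives 100 nM in this assay, the higher of the two numbers recorded so far. Its nearest neighbour, compound 2 `Cc1noc2cc3c(cc12)C1CNCC3C1`, gives 0.13 nM, a far lower number, and the gap between the two lies well beyond the usual scatter. Compound 3 `Cc1ccc2c(c1)C1CNCC2C1` shares the core of compound 1 and differs from it in one place: methyl in place of amino on an aromatic carbon. Within the data shown here, no measured pair shows this exchange directly, so the size of the step can only be anticipated. The loss of the single nitrogen with its donor and acceptor is expected to leave compound 3 somewhat weaker than compound 1, a modest step, though one that may reach beyond the scatter; the estimated step from compound 1 to compound 3 is a 3.0-fold higher number from compound 1 to compound 3 (0.48 log units; beyond the scatter). For compound 3 the estimate in this assay is 300 nM, with a range from 60 nM to 1500 nM.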

Compound 3, inhibition constant: 1.6 nM
Beside the measured number, compound 3's estimate is 190-fold (2.27 log units) above it; measured number below the stated range.
By their numbers in this assay, from the lowest: compound 2; then compound 3; then compound 1.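

In this assay, among these compounds, a 63-fold lower number from compound 1 to compound 3 (1.80 log units; beyond the scatter) comes from a single exchange of one heavy atom on an aromatic carbon of the shared core, and this large step is the first direct reading of how much this position responds to what it carries. It also shows that a low number at this position does not depend on the hydrogen-bond donor and acceptor that leave with amino, since methyl brings neither and compound 3 still gives 1.6 nM in this assay. Nothing among the available data accounts for the size of this step, so the result records its direction and magnitude without a cause.

This remains one pair on one core in one assay, so it cannot say whether the low number belongs to methyl specifically or would also be reached by another small group at the same aromatic carbon, such as a chlorine atom, a hydroxyl or a methoxy group. Nor can it say whether a longer chain, such as ethyl or propyl, would hold the number, lower it further or give part of the step back.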